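The source may hold more compounds than are shown below. What is called first, only, known or untested is meant among the compounds shown, and "the series" means these compounds.

In an ADME assay on Raji cells (Homo sapiens) for cytotoxicity, read by CellTiter-Glo and resazurin assay, with a stated time of 72 h (a higher number here means that more compound is needed for the effect, a lower number that less compound is needed), compound 1 `CC(C)N(Cc1cccc(OCCCCCC(=O)O)c1)C(=O)c1ccccc1` gives only a limit, > 26000 nM. Compound 2 `CCOc1cccc(-c2ccc(C(=O)N(Cc3cccc(OCCCCCC(=O)O)c3)C(C)C)cc2)c1` likewise returns a limit in this assay, > 20800 nM. Compound 3 `CC(C)N(Cc1cccc(OCCCCCC(=O)O)c1)C(=O)c1ccc(-c2cccc(O)c2)cc1` also returns a limit in this assay, > 26000 nM. Two of the three values sit at the limit of > 26000 nM in this assay, at which 2 of the 3 values shown sit, and one at the limit of > 20800 nM in this assay, at which 1 of the 3 values shown sits, so the steps among them cannot be read: a step that the two limits leave unreadable from compound 1 to compound 2, a step that the two limits leave unreadable from compound 3 to compound 2 and a step that the two limits leave unreadable from compound 1 to compound 3 all remain unreadable.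

Compound 4 `CCOC(=O)CCCCCOc1cccc(CN(C(=O)c2ccccc2)C(C)C)c1` is not yet measured. It differs from compound 1 by ethyl in place of hydrogen on an oxygen next to a carbonyl group. The same kind of change was made from compound 3 to compound 2, (ethyl in place of hydrogen on an oxygen on an aromatic ring), but the place differs: there the ethyl enters on an oxygen on an aromatic ring whose other neighbour is an aromatic carbon, whereas in compound 4 it enters on an oxygen next to a carbonyl group whose other neighbour is the carbonyl carbon. The two cores differ as well, by hydrogen in place of 3-hydroxyphenyl on an aromatic carbon. The measured step that the two limits leave unreadable from compound 3 to compound 2 could not be read, and compound 1 itself gives only a limit, > 26000 nM. The expected step that the limit leaves unreadable from compound 1 to compound 4 therefore rests on that limit alone. Compound 4 is estimated at 30000 nM, between 10000 nM and 100000 nM.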

Compound 4, half-maximal effective concentration: > 26000 nM
Compound 4: only a limit was reported; the forecaster's own chance of this, stated with the estimate: 80%; the middle value is on the limit's open side.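

Compound 1 and compound 4 both return only limits in this assay, so the step between them, ethyl in place of hydrogen on an oxygen next to a carbonyl group, cannot be read. The compounds shown leave open the actual half-maximal effective concentration of any of the four compounds, and whether any change among them shifts it at all.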